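Compound 1 to compound 3: fluoro in place of chloro

A few compounds are considered here, and "the series" means these few. Any claim that something is new, unique, unknown or untested is made for them only; others in the source may bear on it.

Of the compounds shown here, two have been measured so far in an in vivo ADME assay on the whole organism (strain CD-1) for pharmacokinetics, with Mus musculus as the target, at a dose of 30 mg/kg by the oral route; on this read-out lower numbers stand for lower oral bioavailability and higher numbers for higher oral bioavailability. Compound 1 (`CCCS(=O)(=O)Nc1ccc(Cl)c(C(=O)Nc2cnc3[nH]nc(OC)c3c2)c1F`) gives 53%, the lower of the two numbers. Compound 2 (`CCCS(=O)(=O)Nc1ccc(F)c(C(=O)Nc2cnc3[nH]cc(Br)c3c2)c1F`) gives 71%, and the gap between them lies beyond the usual scatter. The next compound to be measured is compound 3 (`CCCS(=O)(=O)Nc1ccc(F)c(C(=O)Nc2cnc3[nH]nc(OC)c3c2)c1F`), which keeps the core of compound 1 and carries fluoro in place of chloro on an aromatic carbon. The exchanged atom sits ortho to a large group and para to a (propylsulfonyl)amino group.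

For the measured compounds named here, no two measured compounds differ in one place only, so the series offers no direct precedent for the size of this step. Going by the values given here, the two values show only that numbers in this assay can differ beyond the scatter within this small set, and they cannot be assigned to this exchange. No step beyond the scatter is therefore expected, in either direction. The expected change is a number 4 percentage points higher from compound 1 to compound 3 (within the scatter). For compound 3 the estimated value is 57%, with an expected range from 37% to 77%.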

Compound 3, oral bioavailability: 48%
Compound 3: the middle estimate sits 9 percentage points above what was measured; the measured number falls inside the stated range.
By their numbers in this assay, from the lowest: compounds 3 and 1 (each within the scatter of the next); then compound 2.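

In this assay, for the compounds shown here, the exchange of chloro for fluoro on the aromatic carbon para to a (propylsulfonyl)amino group gives a number 5 percentage points lower from compound 1 to compound 3 (within the scatter), and this pair supplies the first one-place comparison. On the core of compound 1, the two halogens at this position, ortho to a large group and meta to a fluoro group, therefore cannot be told apart by oral bioavailability, although this rests on a single pair and sets no rule for the series. No measured data are at hand that bear on why the two halogens read alike here.

The halogen comparison leaves open whether a group other than a halogen at this position, such as methyl, nitrile or an amine, would keep oral bioavailability in the same range or shift it beyond the scatter. It also remains open whether the same exchange would give a similarly small step on the core of compound 2, since the chloro counterpart of that compound does not appear among those shown here.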